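The source may hold more compounds than are shown below. What is called first, only, known or untested is meant among the compounds shown, and "the series" means these compounds.

Measured in a functional assay on HCT-15 cells (Homo sapiens); a lower number here means that less compound is needed, a higher number that more compound is needed for the effect:
Compound 1 `COC(=O)N1N=C(c2ccc(N(C)C)cc2)OC1c1cc(OC)c(OC)c(OC)c1`: 40 uM
Compound 2 `COc1cc(C2OC(c3ccc(N(C)C)cc3)=NN2C(=O)COC(C)=O)cc(OC)c1OC`: 0.019 uM

Compound 2 holds the lower of these two numbers, well clear of compound 1. Compound 3 `COc1cc(C2OC(c3ccc(N(C)C)cc3)=NN2C(=O)CN(C)C)cc(OC)c1OC` changes compound 2 in one place, with dimethylamino in place of acetoxy on a saturated chain carbon bound to a carbonyl carbon. Within the data shown here, only one measured step bears on this: a 2100-fold lower number from compound 1 to compound 2 (3.32 log units; beyond the scatter), a large one. Among the measured compounds shown here, it shows that this part of the molecule can move the number strongly, but no measured compound carries dimethylamino. A step to a higher number is expected, a 13-fold higher number from compound 2 to compound 3 (1.12 log units; beyond the scatter), smaller than the measured one. The estimated value for compound 3 is 0.25 uM, with a range of 0.02 uM to 3 uM.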

Compound 3, concentration for half-maximal effect: 80 uM
Compound 3: the middle estimate sits 320-fold (2.51 log units) below what was measured; the whole stated range lies below it.
By their numbers in this assay, from the lowest: compound 2; then compounds 1 and 3 (each within the scatter of the next).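

In this assay, dimethylamino in place of acetoxy on a saturated chain carbon bound to a carbonyl carbon gives a 4200-fold higher number from compound 2 to compound 3 (3.62 log units; beyond the scatter) and so shows that the low number of compound 2 depends on the acetoxy group, not merely on a chain at this place. Moving from methoxy to (dimethylamino)methyl on a carbonyl carbon gives a 2.0-fold higher number from compound 1 to compound 3 (0.30 log units; within the scatter) and so leaves the number where methoxy had it. From the compounds shown here alone, whether a hydroxy group or a longer ester chain would keep the low number stays open. No measurement shown here gives a reason for the loss.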